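Methoxycarbonyl for Aminopropyl on the Amine Nitrogen

The source may report more compounds than this note shows. Statements on the series, on what has been measured and on what is new or still open speak of the compounds shown alone.

In an assay on HEK293 cells for displacement of a labelled ligand from Melanocortin receptor 4 (Homo sapiens) (a higher number here means a weaker inhibitor, a lower number a stronger inhibitor), three compounds have been measured:
Compound 1 `CCC(C)C(N)c1cc(C(F)(F)F)ccc1N1CCN(C(=O)CCc2ccc(Cl)cc2Cl)CC1`: 160 nM
Compound 2 `CCC(C)[C@H](NCc1ccccc1F)c1cc(C(F)(F)F)ccc1N1CCN(C(=O)CCc2ccc(Cl)cc2Cl)CC1`: only a limit, > 10000 nM
Compound 3 `CCC(C)[C@H](NC[C@H](C)N)c1cc(C(F)(F)F)ccc1N1CCN(C(=O)CCc2ccc(Cl)cc2Cl)CC1`: 89 nM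

Compound 3 gives the lowest of the two numbers shown, but its step from compound 1, a 1.8-fold lower number from compound 1 to compound 3 (0.25 log units; within the scatter), does not separate the two. Compound 4 `CCC(C)[C@H](NC(=O)OC)c1cc(C(F)(F)F)ccc1N1CCN(C(=O)CCc2ccc(Cl)cc2Cl)CC1` differs from compound 3 by methoxycarbonyl in place of 2-aminopropyl on an amine nitrogen. Among the measured compounds shown here, two measured steps bear on this. The step of a 1.8-fold lower number from compound 1 to compound 3 (0.25 log units; within the scatter) shows that the 2-aminopropyl group itself mattered little. The step of an at least 110-fold lower number from compound 2 to compound 3 (2.05 log units; beyond the scatter) starts from a 2-fluorophenyl group on the same amine nitrogen, where only a limit was reached (the limit of > 10000 nM in this assay, at which 1 of the 3 values shown sits). Methoxycarbonyl, like that group, brings no nitrogen and no hydrogen-bond donor, so a large rise toward weaker binding is expected, a 34-fold higher number from compound 3 to compound 4 (1.53 log units; beyond the scatter). Compound 4 is estimated at 3000 nM, between 500 nM and 20000 nM.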

Compound 4, inhibition constant: 2400 nM
Compound 4: middle estimate off by 1.3-fold (0.10 log units), on the high side; low and high end bracket the measured number.
By their numbers in this assay, from the lowest: compounds 3 and 1 (each within the scatter of the next); then compound 4. At a limit, above all of these: compound 2.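

Methoxycarbonyl on this amine nitrogen clearly weakens binding relative to 2-aminopropyl, with a 27-fold higher number from compound 3 to compound 4 (1.43 log units; beyond the scatter), and relative to the unsubstituted amine, with a 15-fold higher number from compound 1 to compound 4 (1.18 log units; beyond the scatter). Even so, it is not the poorest group here, as 2-fluorobenzyl on the same nitrogen gives an at least 4.1-fold lower number from compound 2 to compound 4 (0.61 log units; beyond the scatter). The value of compound 2 is only a limit: the limit of > 10000 nM in this assay, at which 1 of the 4 values shown sits.

The compounds shown do not separate the effect of adding a carbonyl from that of losing the amine of 2-aminopropyl. An acetyl group, or a longer chain ending in an amine, on this nitrogen would bear on that question.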